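The source may hold more compounds than are shown below. What is called first, only, known or untested is meant among the compounds shown, and "the series" means these compounds.

Compound 3 `CCN(CC)CCn1cnnc1-c1cc(Oc2ccc(NC(=O)Nc3ccccc3C(F)(F)F)cc2F)ccn1` gives 11600 nM in a functional assay on MDA-MB-231 cells (Homo sapiens) for antiproliferative activity, read by MTT assay, with a stated time of 72 h (a lower number here means a stronger inhibitor, a higher number a weaker inhibitor), the highest number shown, although compound 1 `CN(C)CCn1cnnc1-c1cc(Oc2ccc(NC(=O)Nc3ccc(F)c(Cl)c3)cc2F)ccn1` gives 8320 nM, within the scatter of compound 3, while compound 2 `CCN(CC)CCn1cnnc1-c1cc(Oc2ccc(NC(=O)Nc3cccc(C(F)(F)F)c3)cc2F)ccn1` gives 720 nM. Within the data shown here, the one measured step that alters this part of the molecule, a 16-fold higher number from compound 2 to compound 3 (1.21 log units; beyond the scatter), was large. Compound 4 `CCN(CC)CCn1cnnc1-c1cc(Oc2ccc(NC(=O)Nc3ccc(F)c(Cl)c3)cc2F)ccn1` differs from compound 3 by 3-chloro-4-fluorophenyl in place of 2-(trifluoromethyl)phenyl on an amide-type nitrogen. Among the measured compounds shown here, no measured step covers this exact swap, but compound 1 carries the same 3-chloro-4-fluorophenyl and gives 8320 nM, whereas the 3-(trifluoromethyl)phenyl of compound 2 gave a far lower number than compound 3. A drop is therefore expected, a 4.6-fold lower number from compound 3 to compound 4 (0.67 log units; beyond the scatter), though its size is uncertain. Compound 4 is estimated at 2500 nM, within 600 nM to 9000 nM.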

Compound 4, half-maximal inhibitory concentration: 34000 nM
Compound 4: the middle estimate sits 14-fold (1.13 log units) below what was measured; the whole stated range lies below it.
By their numbers in this assay, from the lowest: compound 2; then compounds 1 and 3 (each within the scatter of the next); then compound 4.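

With diethylamino held constant, 3-chloro-4-fluorophenyl on the amide-type nitrogen falls behind both trifluoromethyl-bearing rings (a 2.9-fold higher number from compound 3 to compound 4 (0.47 log units; beyond the scatter); a 47-fold higher number from compound 2 to compound 4 (1.67 log units; beyond the scatter)), so the aryl group strongly shapes the result. The new compound also shows that the amine matters: with the aryl group unchanged, diethylamino in place of dimethylamino gives (a 4.1-fold higher number from compound 1 to compound 4 (0.61 log units; beyond the scatter)). No measurement here explains either shift.

Going by these compounds, how 3-chlorophenyl or 4-fluorophenyl alone would compare remains open. So does whether morpholine in place of diethylamino would change the number.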